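Chloro in place of ethyl: an antiproliferative estimate

The source may report more compounds than this note shows. Statements on the series, on what has been measured and on what is new or still open speak of the compounds shown alone.

compound 1 `O=C1NCCN1c1ccc(S(=O)(=O)Nc2ccc3[nH]ccc3c2)cc1`: 640 nM
compound 2 `CCc1cccc(NS(=O)(=O)c2ccc(N3CCNC3=O)cc2)c1`: 140 nM
compound 3 `COc1cc(NS(=O)(=O)c2ccc(N3CCNC3=O)cc2)cc(OC)c1OC`: 170 nM

These three compounds were tested in a functional assay on CHO-TAX 5-6 cells (Cricetulus griseus) for antiproliferative activity, read by sulforhodamine B assay, with a stated time of 48 h; on this read-out higher numbers stand for weaker inhibition and lower numbers for stronger inhibition. There, compound 2 at 140 nM and compound 3 at 170 nM lie within the scatter of each other. Compound 1 gives a higher number than compound 2, and that gap lies beyond the scatter.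

The next compound to be measured is compound 4 `O=C1NCCN1c1ccc(S(=O)(=O)Nc2cccc(Cl)c2)cc1`. It departs from compound 2 by one change: chloro in place of ethyl on an aromatic carbon. In words, this is chloro in place of ethyl on an aromatic carbon, taking 3-ethylphenyl to 3-chlorophenyl.

Among the compounds with values here, no measured pair shows this change directly, so the expectation rests on a loose comparison. Compound 2 at 140 nM and compound 3 at 170 nM carry different groups yet stay within the scatter, so no step beyond the scatter is expected in this assay. The expected change is a 1.4-fold higher number from compound 2 to compound 4 (0.13 log units; within the scatter). For compound 4 the estimated value is 190 nM, with an expected range from 70 nM to 500 nM.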

Compound 4, half-maximal inhibitory concentration: 58 nM
The estimate for compound 4 lay 3.3-fold (0.52 log units) above the measured number, outside the stated range (below it).
By their numbers in this assay, from the lowest: compound 4; then compounds 2 and 3 (each within the scatter of the next); then compound 1.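

In this assay, within the data shown here, chloro in place of ethyl on this aromatic carbon, meta to a large group, gives a 2.4-fold lower number from compound 2 to compound 4 (0.38 log units; beyond the scatter), the first step in this set between compounds that differ in one place. It shows that this position responds to a single substitution and that ethyl, with its 2 carbon atoms, can give way to a single chlorine atom without a loss of inhibition on this read-out. Nothing available accounts for the size or direction of this step.

The compounds shown leave open how an amine, a nitrile or a longer chain would compare with chloro at this position. They also leave open whether chloro would give a step of similar size on another carbon of the same ring.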